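The source may report more compounds than this note shows. Statements on the series, on what has been measured and on what is new or still open speak of the compounds shown alone.

Measured compounds:
Compound 1, `O=S(=O)(Nc1ccc(-c2nc3ccccc3o2)cc1)c1ccc(Cl)c(C(F)(F)F)c1`, gives 69000 nM in an ADME assay on HEK293 cells (Homo sapiens) for cytotoxicity, read by resazurin assay, with a stated time of 48 h; on this read-out lower numbers stand for higher toxicity in this test and higher numbers for lower toxicity in this test.
Compound 2, `Cc1ccccc1S(=O)(=O)Nc1ccc2oc(-c3ccccc3)nc2c1`, gives 57000 nM in this assay.

Compound 2 has the lower of the two numbers, but its gap to compound 1 lies within the usual scatter, so the two cannot be told apart here. Compound 3, `O=S(=O)(Nc1ccc2oc(-c3ccccc3)nc2c1)c1ccc(O)cc1`, differs from compound 2 in one place: 4-hydroxyphenyl in place of 2-methylphenyl on a sulfonyl sulfur. Among the compounds with values here, no measured pair shows this change, so only the two values above guide the expectation. The step from compound 2 to compound 3 is expected to stay within the scatter, as a 1.1-fold higher number from compound 2 to compound 3 (0.02 log units; within the scatter). Compound 3 is therefore estimated to give about 60000 nM in this assay, between 25000 nM and 150000 nM.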

Compound 3, half-maximal cytotoxic concentration: > 100000 nM
Compound 3: no number, only a limit (the forecaster's own chance of this, stated with the estimate: 20%); middle value at least 1.6-fold (0.22 log units) from the limit.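

Placing 4-hydroxyphenyl instead of 2-methylphenyl on the sulfonyl sulfur gives an at least 1.7-fold higher number from compound 2 to compound 3 (0.24 log units; that floor lies within the scatter). At this place, the new group with its hydrogen-bond donor brings no sign of higher toxicity in this test. Compound 3 has a limit and not a number in this assay: the limit of > 100000 nM in this assay, at which 1 of the 3 values shown sits.

As far as these compounds go, whether compound 3 truly differs from compound 2 stays open, and so does the real size of the step. Also open, from the compounds shown here alone, is how a phenyl group carrying an amine or a carboxylic acid would read on the same sulfonyl sulfur.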